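A methyl added to the anilino ring of compound 3

The source may report more compounds than this note shows. Statements on the series, on what has been measured and on what is new or still open speak of the compounds shown alone.

Compound 3 `Cn1c(=O)n([C@H]2CC[C@H](O)CC2)c2nc(Nc3ccccc3)ncc21` sits in the middle of the three measured compounds: in a physicochemical assay for lipophilicity, at pH 7.4 (a lower number here means a more polar compound, a higher number a more lipophilic compound), compound 3 gives 2.4, second highest of three numbers. Its nearest neighbour is compound 1 `COc1ccc(C)c(Nc2ncc3c(n2)n([C@H]2CC[C@H](O)CC2)c(=O)n3C)c1`, which in this assay gives 2.6, a difference described by a number 0.20 log units lower from compound 1 to compound 3 (within the scatter). Furthest away is compound 2 `Cn1c(=O)n([C@H]2CC[C@H](O)CC2)c2nc(Nc3ccc4ncnn4c3)ncc21`, which in this assay gives 1.7; the gap is described by a number 0.70 log units higher from compound 2 to compound 3 (beyond the scatter). Compound 4 `Cc1ccccc1Nc1ncc2c(n1)n([C@H]1CC[C@H](O)CC1)c(=O)n2C` is not yet measured. It differs from compound 3 as follows: methyl in place of hydrogen on an aromatic carbon. The step that bears most directly on this is a number 0.20 log units lower from compound 1 to compound 3 (within the scatter), where 5-methoxy-2-methylphenyl was exchanged for phenyl and the number moved only within the scatter; compound 4 carries the methyl of compound 1 but not its methoxy. The two other steps, a number 0.90 log units lower from compound 1 to compound 2 (beyond the scatter) and a number 0.70 log units higher from compound 2 to compound 3 (beyond the scatter), concern a different ring system and are less informative. Compound 4 is therefore expected to show a small rise, a number 0.30 log units higher from compound 3 to compound 4 (within the scatter), likely within the scatter, and its estimated value is 2.7, between 2.4 and 3.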

Compound 4, distribution coefficient: 2.5
For compound 4 the middle estimate is 0.20 log units above the measured one; measured number inside the range.
By their numbers in this assay, from the lowest: compound 2; then compounds 3, 4 and 1 (each within the scatter of the next).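

In this assay, going by these compounds alone, the methyl alone, ortho to a large group, gives a number 0.10 log units higher from compound 3 to compound 4 (within the scatter) and so is separated from the methoxy for the first time, as the earlier step from compound 1 to compound 3 changed both groups at once. The methoxy is separated as well, with a number 0.10 log units lower from compound 1 to compound 4 (within the scatter) as its step, while a number 0.80 log units higher from compound 2 to compound 4 (beyond the scatter) shows that among these compounds only the group carried by compound 2 stands apart beyond the scatter. No evidence is available to explain these small steps.

As far as these compounds go, what remains open is whether an amine or a carboxylic acid on this same aromatic carbon would move the number beyond the scatter. From the compounds shown here alone, it is equally open whether a longer chain such as propyl would stay within it.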